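The source may report more compounds than this note shows. Statements on the series, on what has been measured and on what is new or still open speak of the compounds shown alone.

Series notes, cytotoxicity branch. The shared core of compound 1 `O=C(Nc1ccc2nc(NC(=O)C3CCCCC3)sc2c1)c1ccccc1Cl` carries a cyclohexanecarbonyl amide on one side and a (2-chlorophenyl)carbonyl amide on the other. Within the data shown here, in a functional assay on WI-38 VA13 cells (Homo sapiens) for cytotoxicity (on this read-out lower numbers stand for an effect already at smaller amounts and higher numbers for an effect only at larger amounts of compound), compound 1 gives 0.025 ug/mL, the lowest of the two numbers measured so far. Compound 2 `CC(=O)Nc1ccc2nc(NC(=O)C3CCCCC3)sc2c1` keeps everything but has methyl in place of 2-chlorophenyl on the carbonyl carbon; in this assay compound 2 gives 2.7 ug/mL. Among the measured compounds shown here, the step of a 110-fold higher number from compound 1 to compound 2 (2.03 log units; beyond the scatter) is the only measured change at this position and shows that removing the aromatic ring from the carbonyl costs a great deal.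

Compound 3 `Cc1cc(C(=O)Nc2ccc3nc(NC(=O)C4CCCCC4)sc3c2)n(C)n1` is not yet measured. Relative to compound 1 the change is 1,3-dimethyl-1H-pyrazol-5-yl in place of 2-chlorophenyl on a carbonyl carbon. An aromatic ring of the same heavy-atom count stays on the carbonyl, so the large loss seen in a 110-fold higher number from compound 1 to compound 2 (2.03 log units; beyond the scatter) is not the template; a smaller shift is expected. The step from compound 1 to compound 3 is therefore estimated as a 6.0-fold higher number from compound 1 to compound 3 (0.78 log units; beyond the scatter), toward a higher number. For compound 3 in this assay the expected value is 0.15 ug/mL, with a range from 0.03 ug/mL to 1 ug/mL.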

Compound 3, half-maximal effective concentration: 0.12 ug/mL
For compound 3 the middle estimate is 1.3-fold (0.10 log units) above the measured one, within the range that was stated.
By their numbers in this assay, from the lowest: compound 1; then compound 3; then compound 2.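

The step of a 23-fold lower number from compound 2 to compound 3 (1.35 log units; beyond the scatter) shows that in this assay most of what was lost with methyl returns once an aromatic ring sits on the carbonyl carbon again, and that this ring need not be the six-membered carbon ring of 2-chlorophenyl, as a five-membered ring with 2 hetero atoms also serves. The two aromatic groups are still not interchangeable: the step of a 4.8-fold higher number from compound 1 to compound 3 (0.68 log units; beyond the scatter) lies beyond the scatter even though both groups have 7 heavy atoms, so the numbers at this position rise from 2-chlorophenyl through 1,3-dimethyl-1H-pyrazol-5-yl to methyl. Nothing at hand speaks to what lies behind either step.

Open, going by these compounds, is whether the chlorine or the ring of the 2-chlorophenyl group accounts for the low number of compound 1, which plain phenyl on this carbonyl would help to separate, and whether a saturated ring such as cyclohexyl would behave like the aromatic groups or like methyl. On these data alone, the cyclohexanecarbonyl amide also stays constant in all three compounds, so the effect of a morpholine or a carboxylic acid on that side remains unknown.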